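Extending an ethyl chain to hexyl

This account rests on a few compounds, and the source may have more. Where it says the series, first, only, none or still open, it means among the compounds named here.

Measured in a functional assay, with stated times of 30 s and 6 min, in the presence of a further agent that is not named here; a higher number here means a weaker inhibitor, a lower number a stronger inhibitor
Compound 1 `CCOc1cc(OC)c(Br)cc1C(C)=O` gives 37900000 nM
Compound 2 `CCOc1cc(OC)ccc1C(C)=O` gives 6600000 nM

For the measured compounds named here, compound 2 has the lower of the two numbers so far, which makes it the stronger inhibitor of the pair. The change leading to compound 3 `CCCCCCOc1cc(OC)ccc1C(C)=O` is butyl in place of hydrogen on a saturated chain carbon, two bonds along the chain from an oxygen on an aromatic ring and the same difference reads ethyl to hexyl. Going by the values given here, the only measured step (a 5.7-fold lower number from compound 1 to compound 2 (0.76 log units; beyond the scatter)) swapped bromo for hydrogen on an aromatic carbon and was modest. It leaves the chain untouched, so it offers only a rough size and no firm direction. A modest drop in this assay is still expected, with a size of a 3.3-fold lower number from compound 2 to compound 3 (0.52 log units; beyond the scatter) as the estimate. Compound 3 is estimated at 2000000 nM (expected range 300000 nM to 9000000 nM).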

Compound 3, half-maximal inhibitory concentration: 18000000 nM
For compound 3 the middle estimate is 9.0-fold (0.95 log units) below the measured one; the whole stated range lies below it.
By their numbers in this assay, from the lowest: compound 2; then compound 3; then compound 1.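

In this assay, going from ethyl to hexyl gives a 2.7-fold higher number from compound 2 to compound 3 (0.44 log units; beyond the scatter), so at this position the added butyl weakens inhibition modestly rather than strengthening it. For the compounds shown here, this is the first direct reading of the chain itself, as the earlier step changed only bromo to hydrogen on an aromatic carbon. No available measurement gives a reason for this loss.

Going by these compounds, whether the number rises steadily with chain length remains open, and a propyl chain would help to show that. Also open, on these data alone, is how a chain ending in an amine or a carboxylic acid would compare.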